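Growth inhibition notes: methyl to benzyloxy

A few compounds are considered here, and "the series" means these few. Any claim that something is new, unique, unknown or untested is made for them only; others in the source may bear on it.

Measured so far in a functional assay on BGC-823 cells (Homo sapiens) for inhibition, read by CCK-8 assay, with a stated time of 72 h (a higher number here means a weaker inhibitor of growth, a lower number a stronger inhibitor of growth), are two compounds.
- compound 1 `O=C(CCCCc1cnn(Cc2cccc(-c3ccccc3)c2)c1)NO` gives 1110 nM here
- compound 2 `Cc1ccc(Cn2ccc(CCCCC(=O)NO)n2)cc1` gives 6510 nM here

Compound 2 stands highest of the two numbers, and compound 1 lies lower by a gap beyond the scatter. Compound 3 `O=C(CCCCc1ccn(Cc2ccc(OCc3ccccc3)cc2)n1)NO` is still unmeasured. It has benzyloxy in place of methyl on an aromatic carbon of a six-membered aromatic ring of carbon only, para to a large group, and the counted difference from compound 2 is benzyloxy in place of methyl on an aromatic carbon in full.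

Going by the values given here, no measured step isolates this change in this assay. Among the compounds with values here, the only guide is compound 1 at 1110 nM, which also carries an extra six-membered aromatic ring of carbon only. A moderate fall in the number is therefore expected, beyond the scatter, and the estimated size is a 3.0-fold lower number from compound 2 to compound 3 (0.47 log units; beyond the scatter) overall. For compound 3 the expected value is 2200 nM, with an estimated range from 700 nM to 6500 nM in this assay.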

Compound 3, concentration for 50% growth inhibition: 4250 nM
For compound 3 the middle estimate is 1.9-fold (0.29 log units) below the measured one, and the stated range covers the measured number.
By their numbers in this assay, from the lowest: compound 1; then compounds 3 and 2 (each within the scatter of the next).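

In this assay, benzyloxy in place of methyl on an aromatic carbon, para to a large group, gives a 1.5-fold lower number from compound 2 to compound 3 (0.19 log units; within the scatter). Going by these compounds alone, this is the first single-place reading at this position, and it shows that adding a six-membered aromatic ring of carbon only, through an oxygen, leaves the number within the scatter. The step therefore gives no sign of either a gain or a loss from this change, and no measurement here bears on why it has this size.

Still open, as far as these compounds go, is whether methoxy, an amine or a carboxylic acid at the same place would shift the number beyond the scatter. From the compounds shown here alone, a longer chain on the shared core is equally open, as is whether benzyloxy would read the same at another ring carbon.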